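Swapping the amine on the core: cytotoxicity notes

This account rests on a few compounds, and the source may have more. Where it says the series, first, only, none or still open, it means among the compounds named here.

Compound 1 `CN(Cc1cn2c(N3CCC(N)CC3)cccc2n1)[C@H]1CCCc2cccnc21` is the reference point of this pair. Going by the values given here, in an ADME assay on HOS cells (Homo sapiens) for cytotoxicity (a higher number here means that more compound is tolerated, a lower number that less compound is tolerated), compound 1 gives 6300 nM, the single numeric reading in the set. Compound 2 `CN1CCN(c2cccc3nc(CN(C)[C@H]4CCCc5cccnc54)[nH]c23)CC1` is the other measured member. In this assay compound 2 gives > 5000 nM, which is a limit of the assay and not a number. The remaining entry is the limit of > 5000 nM in this assay, at which 1 of the 2 values shown sits. Compound 3 `CN1CCC(N(C)c2cccc3nc(CN(C)[C@H]4CCCc5cccnc54)cn23)C1` is not yet measured in this assay; it differs from compound 1 by methyl(1-methylpyrrolidin-3-yl)amino in place of 4-aminopiperidin-1-yl on an aromatic carbon. Among the compounds with values here, no step between two measured compounds is available to calibrate this change, so the expected step of no change at the digits printed from compound 1 to compound 3 (within the scatter) is one of no size beyond the usual scatter, in either direction. For compound 3 the estimate in this assay is therefore 6300 nM, within 2500 nM to 16000 nM.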

Compound 3, half-maximal cytotoxic concentration: 10800 nM
Estimate against measurement, compound 3: 1.7-fold (0.23 log units) below; the range from low to high includes it.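

In this assay the swap at this position gives a 1.7-fold higher number from compound 1 to compound 3 (0.23 log units; within the scatter). The aromatic carbon next to the ring nitrogen therefore carries methyl(1-methylpyrrolidin-3-yl)amino in place of 4-aminopiperidin-1-yl, with the hydrogen-bond donor gone and a five-membered ring replacing the six-membered one, and the readings do not separate the two compounds. This is the only step between measured compounds in the set, and the entry for compound 2 is a limit of the assay and not a number: the limit of > 5000 nM in this assay, at which 1 of the 3 values shown sits.

On these data alone, what a carboxylic acid or a morpholin-4-yl group on this carbon would give in this assay stays open. The donor count and the ring size change together in this single step, and the compounds shown do not tell the two apart.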